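A few compounds are considered here, and "the series" means these few. Any claim that something is new, unique, unknown or untested is made for them only; others in the source may bear on it.

Compound 2, `Cc1cc(=O)n(-c2ccc(Br)cc2F)nc1C(=O)Nc1ccc(Oc2ncnc3c2ccn3C)c(F)c1`, gives in a functional assay on MCF7 cells (Homo sapiens) for cytotoxicity, read by MTT assay, with a stated time of 72 h (on this read-out higher numbers stand for weaker inhibition and lower numbers for stronger inhibition), only a limit, > 60000 nM, not a number. Compound 1, `Cc1ccc(-n2nc(C(=O)Nc3ccc(Oc4ncnc5[nH]ccc45)c(F)c3)c(C)cc2=O)cc1`, shares the amide and diaryl ether with compound 2. In this assay compound 1 gives 18900 nM. Both sit weak, with one of the two values at the limit (the limit of > 60000 nM in this assay, at which 1 of the 2 values shown sits). Compound 3, `Cc1ccc(-n2nc(C(=O)Nc3ccc(Oc4ncnc5c4ccn5C)c(F)c3)c(C)cc2=O)cc1`, is compound 2 after (4-methylphenyl in place of 4-bromo-2-fluorophenyl on an aromatic nitrogen). Within the data shown here, no measured pair isolates this change, so the expected step from compound 2 to compound 3 is tentative and small, an at least 2.0-fold lower number from compound 2 to compound 3 (0.30 log units; that floor lies within the scatter), leaning toward stronger inhibition. Compound 3 is estimated at 30000 nM, within 10000 nM to 90000 nM.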

Compound 3, half-maximal inhibitory concentration: > 60000 nM
Compound 3: only a limit was reported (the forecaster's own chance of this, stated with the estimate: 35%); at least 2.0-fold (0.30 log units) between middle value and limit.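

In this assay compound 3 gives > 60000 nM, which is a limit and not a number. The step from the aryl change on the aromatic nitrogen cannot be read, since both compounds in that pair stand at the limit: the limit of > 60000 nM in this assay, at which 2 of the 3 values shown sit.

The readable change is methyl in place of hydrogen on an aromatic nitrogen, which gives an at least 3.1-fold higher number from compound 1 to compound 3 (0.50 log units; beyond the scatter), the first sign in this series that this position affects the read-out.

Still open, going by these compounds, is whether 4-bromo-2-fluorophenyl and 4-methylphenyl differ when hydrogen replaces that methyl. An ethyl or aminoethyl chain at the same nitrogen also remains to be placed.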